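This account rests on a few compounds, and the source may have more. Where it says the series, first, only, none or still open, it means among the compounds named here.

In a functional assay on PC-3 cells (Homo sapiens) for antiproliferative activity, read by WST assay, with a stated time of 3 days (on this read-out higher numbers stand for weaker inhibition and lower numbers for stronger inhibition), compound 1 (`CCCCOc1c(-c2cc(OC)c(OC)c(OC)c2)oc2ccccc2c1=O`) gives 12800 nM and compound 3 (`CCCC(C)Oc1c(-c2cc(OC)c(OC)c(OC)c2)oc2ccccc2c1=O`) gives 49300 nM as the higher of these two numbers. Compound 2 (`CCCCCCCOc1c(-c2cc(OC)c(OC)c(OC)c2)oc2ccccc2c1=O`) reads > 50000 nM as a limit of the assay. Compound 4 (`CCCN(CCC)CCCOc1c(-c2cc(OC)c(OC)c(OC)c2)oc2ccccc2c1=O`) is still unmeasured and carries 3-(dipropylamino)propyl in place of 1-methylbutyl on an oxygen on an aromatic ring. Adding the methyl of that 1-methylbutyl came with a 3.9-fold higher number from compound 1 to compound 3 (0.59 log units; beyond the scatter) and this methyl now leaves, which points to a lower number. Lengthening the chain came with an at least 3.9-fold higher number from compound 1 to compound 2 (0.59 log units; beyond the scatter) and this tempers that hope, since the entering chain is larger. Both steps lie beyond the scatter. In this assay a modest fall is therefore expected (a 4.1-fold lower number from compound 3 to compound 4 (0.61 log units; beyond the scatter)). The estimate for compound 4 is 12000 nM with an expected range from 3000 nM to 45000 nM in this span.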

Compound 4, half-maximal inhibitory concentration: 16800 nM
For compound 4 the middle estimate is 1.4-fold (0.15 log units) below the measured one; the range from low to high includes it.
By their numbers in this assay, from the lowest: compounds 1 and 4 (each within the scatter of the next); then compound 3. At a limit, above all of these: compound 2.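

A much larger group on this oxygen need not cost activity: 3-(dipropylamino)propyl gives a 2.9-fold lower number from compound 3 to compound 4 (0.47 log units; beyond the scatter), and against the unbranched butyl chain it gives a 1.3-fold higher number from compound 1 to compound 4 (0.12 log units; within the scatter), which leaves those two level. Chain size alone therefore does not set the number, since a chain carrying a nitrogen reads differently from the all-carbon heptyl chain. That last step, an at least 2.9-fold lower number from compound 2 to compound 4 (0.47 log units; beyond the scatter), is only a floor: the limit of > 50000 nM in this assay, at which 1 of the 4 values shown sits.

With a single amine among the compounds shown, it remains open how a shorter dimethylamino chain, a piperidine ring or a carboxylic acid at this oxygen would read.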